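The compounds below may be only part of what the source reports. "The series", "measured", "known", "first", "only" and "open" are said of these compounds alone.

Measured so far:
compound 1 `COc1ncccc1C(=O)NCCC1CCN(S(=O)(=O)NC(=O)NC[C@H]2C[C@@H]3C=C[C@@H]2C3)CC1` gives 20% in a functional assay on the whole organism (blood) with Rattus norvegicus as the target, with stated times of 24 h and 1 h, at a dose of 5 mg/kg by the intraperitoneal route; a lower number here means a weaker effect, a higher number a stronger effect of the compound at the dose given
compound 2 `COc1ncccc1C(=O)NCCC1CCN(S(=O)(=O)NC(=O)NC[C@@H]2C[C@@H]3CC[C@@H]2O3)CC1` gives 34% in the same assay

Compound 2 stands highest of the two numbers; its nearest neighbour is compound 1, reached by a number 14 percentage points higher from compound 1 to compound 2 (beyond the scatter). Compound 3 `COc1ncccc1C(=O)NCCC1CCN(S(=O)(=O)NC(=O)NCC2CCCCO2)CC1` differs from compound 2 by a group of 6 heavy atoms (5 carbon, 1 oxygen; one six-membered non-aromatic ring with 1 hetero atom) in place of a group of 7 heavy atoms (6 carbon, 1 oxygen; 2 five-membered non-aromatic rings with 1 hetero atom each), on a saturated chain carbon bound to an amide-type nitrogen. For the measured compounds named here, the only measured step, a number 14 percentage points higher from compound 1 to compound 2 (beyond the scatter), swaps one bicyclic group for another at the same place and does not parallel the move to a single six-membered ring, so it gives only weak guidance. A small loss, within or barely beyond the scatter, is expected: a number 6 percentage points lower from compound 2 to compound 3 (within the scatter). Compound 3 is therefore estimated at 28%, between 10% and 45%.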

Compound 3, a percentage reported as activity, at one dose (the size of the read-out at that dose, not a potency): 12%
Compound 3: the middle estimate sits 16 percentage points above what was measured; low and high end bracket the measured number.
By their numbers in this assay, from the lowest: compounds 3 and 1 (each within the scatter of the next); then compound 2.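

At this saturated chain carbon bound to an amide-type nitrogen, a ring oxygen alone is not enough for the higher number: oxan-2-yl also holds one oxygen, yet this assay shows a number 22 percentage points lower from compound 2 to compound 3 (beyond the scatter) for the loss of the two five-membered rings. The all-carbon group and oxan-2-yl cannot be told apart, with a number 8 percentage points lower from compound 1 to compound 3 (within the scatter) as their step.

As far as these compounds go, whether a morpholine ring or an open methoxyethyl chain at this place would match compound 2 remains open. Why these groups differ also remains open, as no supporting evidence bears on this result.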